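From bromo to trifluoromethyl: a small step expected

The source may report more compounds than this note shows. Statements on the series, on what has been measured and on what is new or still open speak of the compounds shown alone.

Compound 1 `O=[N+]([O-])c1ccc(S(=O)(=O)n2c(-c3cn(-c4ccccc4)nc3-c3ccc(C(F)(F)F)cc3)nc3ccccc32)cc1`: 1070 nM
Compound 2 `O=S(=O)(c1ccc(Br)cc1)n1c(-c2cn(-c3ccccc3)nc2-c2ccc(C(F)(F)F)cc2)nc2ccccc21`: 2160 nM

In a functional assay on HepG2 cells (Homo sapiens) for antiproliferative activity, read by MTT assay, with a stated time of 24 h (on this read-out lower numbers stand for stronger inhibition and higher numbers for weaker inhibition), compound 2 gives 2160 nM, the higher of the two numbers and so the weaker inhibition of the pair. Compound 3 `O=S(=O)(c1ccc(C(F)(F)F)cc1)n1c(-c2cn(-c3ccccc3)nc2-c2ccc(C(F)(F)F)cc2)nc2ccccc21` has trifluoromethyl in place of bromo on an aromatic carbon, para to a large group: trifluoromethyl in place of bromo on an aromatic carbon. Going by the values given here, only one measured step bears on this change, and it swaps the same group for another: a 2.0-fold higher number from compound 1 to compound 2 (0.31 log units; beyond the scatter). That step is modest, so in this assay no larger step is expected here, and most likely none beyond the scatter, leaning slightly towards a lower number. The expected step is a 1.4-fold lower number from compound 2 to compound 3 (0.13 log units; within the scatter). For compound 3 the estimated value is 1600 nM, with an expected range of 800 nM to 3200 nM.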

Compound 3, half-maximal inhibitory concentration: 1120 nM
For compound 3 the middle estimate is 1.4-fold (0.15 log units) above the measured one; low and high end bracket the measured number.
By their numbers in this assay, from the lowest: compounds 1, 3 and 2 (each within the scatter of the next, the first and the last beyond it).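

Trifluoromethyl on this aromatic carbon cannot be told apart from either earlier group: the change gives a 1.9-fold lower number from compound 2 to compound 3 (0.29 log units; within the scatter), and replacing nitro gives a 1.0-fold higher number from compound 1 to compound 3 (0.02 log units; within the scatter). Among these three groups, only nitro and bromo lie beyond the scatter of each other, and only narrowly, so exchanging them at this place moves the number little. No measurement available here explains this result. As far as these compounds go, whether an amine, a carboxylic acid or a hydroxyl group at this place would shift the number much further remains open.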